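Removing a trifluoromethyl to leave a phenol

The compounds below may be only part of what the source reports. "The series", "measured", "known", "first", "only" and "open" are said of these compounds alone.

Measured so far:
compound 1 `COc1cc2c(Oc3ccc(NC(=O)N/N=C/c4ccc(C(F)(F)F)cc4)cc3F)ccnc2cc1OCCCN1CCCC1` gives 790 nM in a functional assay on A549 cells (Homo sapiens) for cytotoxicity, read by MTT assay, with a stated time of 72 h; a higher number here means a weaker inhibitor, a lower number a stronger inhibitor;
compound 2 `COc1ccc(/C=N/NC(=O)Nc2ccc(Oc3ccnc4cc(OCCCN5CCCCC5)c(OC)cc34)c(F)c2)cc1` gives 540 nM in this assay;
compound 3 `COc1cc2c(Oc3ccc(NC(=O)N/N=C/c4ccc(OC(F)(F)F)cc4)cc3F)ccnc2cc1OCCCN1CCCCC1` gives 590 nM in this assay.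

Compound 3 stands second highest of the three numbers, with compound 2 nearest and compound 1 furthest, both within the scatter. Compound 4 `COc1cc2c(Oc3ccc(NC(=O)N/N=C/c4ccc(O)cc4)cc3F)ccnc2cc1OCCCN1CCCCC1` differs from compound 3 by hydrogen in place of trifluoromethyl on an oxygen on an aromatic ring. The one measured step at the same place, a 1.1-fold higher number from compound 2 to compound 3 (0.04 log units; within the scatter), lay within the scatter, so changing the group on this oxygen has so far shown no effect that stands out. Compound 4 is therefore expected to show a step of a 1.1-fold higher number from compound 3 to compound 4 (0.04 log units; within the scatter), not beyond the scatter. The estimate for compound 4 is 650 nM, with a range from 300 nM to 1500 nM.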

Compound 4, half-maximal inhibitory concentration: 780 nM
For compound 4 the middle estimate is 1.2-fold (0.08 log units) below the measured one; the measured number falls inside the stated range.
By their numbers in this assay, from the lowest: compounds 2, 3, 4 and 1 (each within the scatter of the next).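

Taking the trifluoromethyl off the oxygen to leave a hydroxy changes little in this assay (a 1.3-fold higher number from compound 3 to compound 4 (0.12 log units; within the scatter)), and the comparison with the methyl-capped compound reads the same way (a 1.4-fold higher number from compound 2 to compound 4 (0.16 log units; within the scatter)). At this position, then, a free hydroxy fits alongside the two capped oxygens: methyl, trifluoromethyl and hydrogen on this oxygen all give numbers within the scatter of one another. Still open, from the compounds shown here alone, is whether the oxygen itself matters, which an amine in its place would test, and whether a longer chain, such as propyl, on the oxygen would behave the same way. No measurement at hand offers an explanation for this flat result.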